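A few compounds are considered here, and "the series" means these few. Any claim that something is new, unique, unknown or untested is made for them only; others in the source may bear on it.

Measured so far:
In an assay on membranes from striatum with 5-hydroxytryptamine receptor 4 (Rattus norvegicus) as the target (a higher number here means a weaker inhibitor, a lower number a stronger inhibitor), compound 1 `CCCCN1CCC(CNC(=O)c2cc(Cl)c([N+](=O)[O-])c3[nH]cnc23)CC1` gives 44.7 nM.
Compound 2 `CCCCN1CCC(CNC(=O)c2cc(Br)c([N+](=O)[O-])c3[nH]cnc23)CC1` gives 47.9 nM in this assay.

Among the compounds with values here, compound 2 holds the higher of the two numbers recorded in this assay, but its only neighbour is compound 1, and the step of a 1.1-fold higher number from compound 1 to compound 2 (0.03 log units; within the scatter), bromo in place of chloro on an aromatic carbon, lies within the scatter. On the numbers shown the two compounds are indistinguishable.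

Compound 3 `CCCCN1CCC(CNC(=O)c2cc(Br)c(N)c3[nH]cnc23)CC1` is the next member, not yet measured. It differs from compound 2 by amino in place of nitro on an aromatic carbon. Within the data shown here, no measured step touches this position or this kind of exchange; the single step available, from chloro to bromo, does not bear on it. There is therefore no basis in the data for expecting a shift in this assay in either direction, and the estimate stays close to the value of compound 2, with a broad range to reflect the lack of any guiding step. The expected step is a 1.3-fold higher number from compound 2 to compound 3 (0.10 log units; within the scatter). For compound 3 the expected value in this assay is 60 nM, with a range from 10 nM to 350 nM.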

Compound 3, inhibition constant: 27.5 nM
Estimate against measurement, compound 3: 2.2-fold (0.34 log units) above; the measured number falls inside the stated range.
By their numbers in this assay, from the lowest: compounds 3, 1 and 2 (each within the scatter of the next).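

Working from the position para to a large group, in this assay the exchange of nitro for amino gives a 1.7-fold lower number from compound 2 to compound 3 (0.24 log units; within the scatter), so this first reading at the position shows no separation between the two groups. Nitro, with 3 heavy atoms and 0 hydrogen-bond donors, gives way to amino, with 1 heavy atom and 1 hydrogen-bond donor, and this difference in the substituent leaves the number within the scatter, whereas the earlier pair spoke only to chloro and bromo at a different aromatic carbon. No measurement is available to account for this result.

The compounds shown leave open whether hydrogen, methoxy or an acetamide at this position would stay within the scatter of compound 3, and whether amino would read the same with chloro in place of the bromo group. They also leave open how a longer chain in place of the butyl chain, or a carboxylic acid on the aromatic ring, would read in this assay.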